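The source may hold more compounds than are shown below. What is called first, only, known or untested is meant among the compounds shown, and "the series" means these compounds.

In a functional assay on HeLa cells (Homo sapiens) for antiproliferative activity, read by CCK-8 assay, with a stated time of 72 h (on this read-out higher numbers stand for weaker inhibition and lower numbers for stronger inhibition), compound 1 (`Nc1ccccc1NC(=O)c1ccc(Cn2cnc3c(Nc4ccccc4)nc(Cl)nc32)cc1`) gives 2920 nM. Compound 2 (`CC(C)n1cnc2c(NCc3ccc(C(=O)Nc4ccccc4N)cc3)nc(Cl)nc21`) gives 2130 nM and compound 3 (`CCCCn1cnc2c(Nc3ccccc3)nc(NCOCc3ccc(C(=O)Nc4ccccc4N)cc3)nc21`) gives 3290 nM. Both numbers lie within the usual scatter of the value for compound 1, so compound 1 stands level with them. Compound 4 (`Nc1ccccc1NC(=O)c1ccc(Cn2cnc3c(Nc4cccc(Cl)c4)nc(Cl)nc32)cc1`) keeps the core of compound 1 and differs in one place: chloro in place of hydrogen on an aromatic carbon, which turns phenyl into 3-chlorophenyl. Among the measured compounds shown here, no measured pair here shows what such a change does in this assay, so only a small step towards stronger inhibition is expected, not clearly beyond the scatter. The expected step is a 1.6-fold lower number from compound 1 to compound 4 (0.21 log units; within the scatter). For compound 4 the estimated value is 1800 nM, with an expected range from 700 nM to 4500 nM.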

Compound 4, half-maximal inhibitory concentration: 11300 nM
Estimate against measurement, compound 4: 6.3-fold (0.80 log units) below, outside the stated range (above it).
By their numbers in this assay, from the lowest: compounds 2, 1 and 3 (each within the scatter of the next); then compound 4.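

In this assay, turning phenyl into 3-chlorophenyl gives a 3.9-fold higher number from compound 1 to compound 4 (0.59 log units; beyond the scatter) and points towards weaker inhibition, the first difference in this set to lie beyond the scatter. Among the compounds shown here, a single chlorine on this aromatic carbon is thus enough to shift the read-out, which the earlier compounds, level with one another, could not show. From the compounds shown here alone, whether a fluoro, a methoxy or an amine on the same carbon would shift the number in the same way remains open. Nothing available here explains the step.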